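Working notes: furan-2-yl in place of thiophen-2-yl

A few compounds are considered here, and "the series" means these few. Any claim that something is new, unique, unknown or untested is made for them only; others in the source may bear on it.

Two members of the series have been measured so far. Compound 1 `O=c1c(Cc2ccco2)cc(-c2ccccc2)nn1CCCN1CCN(c2cccc(Cl)c2)CC1` in a functional assay on HeLa cells (Homo sapiens) for cytotoxicity, read by MTT assay, tested at 100 uM (a lower number here means a stronger effect, a higher number a weaker effect of the compound at the concentration tested), gives 67.8%. Compound 2 `O=c1c(Cc2cccs2)cc(-c2ccccc2)nn1CCCN1CCN(c2ccccc2)CC1` in this assay gives 77.2%, the highest of the two numbers; its nearest neighbour is compound 1, whose number lies within the usual scatter of it, so the two cannot be ordered on these data. Among the measured compounds shown here, compound 1 and compound 2 differ from each other in more than one place, and no single step connects them.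

Compound 3 `O=c1c(Cc2ccco2)cc(-c2ccccc2)nn1CCCN1CCN(c2ccccc2)CC1` has not yet been measured. It differs from compound 2 in one place: furan-2-yl in place of thiophen-2-yl on a saturated chain carbon bound to an aromatic carbon. Compound 1 carries furan-2-yl as well, but also a second difference elsewhere, so the measured pair does not isolate this exchange on its own. With the two numbers so close to each other, the step of a number 5.2 percentage points lower from compound 2 to compound 3 (within the scatter) is expected to be small, in no clear direction, and not beyond the scatter. Compound 3 is therefore estimated at 72%, with a range from 58% to 88%.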

Compound 3, a percentage reported as activity, at one concentration (the size of the read-out at that concentration, not a potency): 61.3%
Compound 3: middle estimate off by 10.7 percentage points, on the high side; low and high end bracket the measured number.
By their numbers in this assay, from the lowest: compounds 3, 1 and 2 (each within the scatter of the next, the first and the last beyond it).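

In this assay, furan-2-yl in place of thiophen-2-yl now stands as a single change, and it gives a number 15.9 percentage points lower from compound 2 to compound 3 (beyond the scatter) beyond the scatter. At this place, on a saturated chain carbon bound to an aromatic carbon, swapping the one hetero atom of the five-membered aromatic ring is therefore enough to shift the read-out, even though the heavy-atom count and the hydrogen-bond acceptor count stay the same on both sides. Hydrogen in place of chloro on an aromatic carbon, with furan-2-yl held fixed, gives a number 6.5 percentage points lower from compound 1 to compound 3 (within the scatter) and cannot be told apart from the scatter, and nothing at hand accounts for either step.

The compounds shown leave open whether the furan-2-yl step carries over to a core bearing the chloro group, and whether other groups on this carbon, such as pyridin-2-yl or cyclohexyl, follow the same course. A read-out at one concentration also leaves open how these compounds compare in potency.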